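The source may hold more compounds than are shown below. What is called first, only, known or untested is meant among the compounds shown, and "the series" means these compounds.

- compound 1 `O=C(CC1CCCCCC1)N1CCC(c2nc(-c3ccc4ccccc4n3)no2)CC1` gives 840 nM in a functional assay on Shh Light II cells (Mus musculus) for inhibition, read by a luciferase reporter; a lower number here means a stronger inhibitor, a higher number a weaker inhibitor
- compound 2 `O=C(Nc1ccccc1C(F)(F)F)N1CCC(c2nc(-c3ccc4ccccc4n3)no2)CC1` gives 700 nM in this assay
- compound 3 `O=C(Nc1cccc2cccnc12)N1CCC(c2nc(-c3ccc4ccccc4n3)no2)CC1` gives 1400 nM in this assay

Compound 3 stands at 1400 nM and cannot be separated from the other two: a 1.7-fold higher number from compound 1 to compound 3 (0.22 log units; within the scatter) and a 2.0-fold higher number from compound 2 to compound 3 (0.30 log units; within the scatter) are both within the scatter.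

Compound 4 `O=C(OCc1ccccc1)N1CCC(c2nc(-c3ccc4ccccc4n3)no2)CC1` is still unmeasured. It keeps the shared core and carries benzyloxy in place of (quinolin-8-yl)amino on a carbonyl carbon.

Going by the values given here, the steps that bear on this change are those at the same carbonyl carbon. Besides the two above, these include a 1.2-fold lower number from compound 1 to compound 2 (0.08 log units; within the scatter), also within the scatter. Among the compounds with values here, three different groups at this place therefore give values that cannot be told apart, although benzyloxy itself has no measured precedent here.

No step beyond the scatter is expected in this assay. The expected change is a 1.4-fold lower number from compound 3 to compound 4 (0.15 log units; within the scatter), which stays within the scatter. The estimate for compound 4 is 1000 nM, with an expected range from 400 nM to 2500 nM.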

Compound 4, half-maximal inhibitory concentration: > 2500 nM
Compound 4: only a limit was reported (the forecaster's own chance of this, stated with the estimate: 5%); middle value at least 2.5-fold (0.39 log units) from the limit.
By their numbers in this assay, from the lowest: compounds 2, 1 and 3 (each within the scatter of the next). At a limit, above all of these: compound 4.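

In this assay compound 4 is recorded only as a limit, > 2500 nM. Cycloheptylmethyl, (2-(trifluoromethyl)phenyl)amino and (quinolin-8-yl)amino could not be told apart on this carbonyl carbon, whereas benzyloxy gives the first steps at this place that lie beyond the scatter: an at least 3.5-fold higher number from compound 2 to compound 4 (0.55 log units; beyond the scatter) and an at least 2.9-fold higher number from compound 1 to compound 4 (0.47 log units; beyond the scatter). The direct exchange of (quinolin-8-yl)amino for benzyloxy remains unresolved, since its floor does not clear the scatter: an at least 1.7-fold higher number from compound 3 to compound 4 (0.25 log units; that floor lies within the scatter).

The limit leaves open how far compound 4 really lies from the other three. Also open, going by these compounds, is whether the step follows the oxygen or the benzyl part of the new group, a question that benzylamino on the same carbonyl carbon would address.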